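The source may report more compounds than this note shows. Statements on the series, on what has been measured and on what is new or still open speak of the compounds shown alone.

Notes on the series in a functional assay on MDA-MB-231 cells (Homo sapiens) for cytotoxicity, read by cell counting, with a stated time of 48 h; on this read-out lower numbers stand for stronger inhibition and higher numbers for weaker inhibition. Compound 1 `Cc1ccc(-n2cc(COc3cccc4cnc(Nc5cccc(Cl)c5)nc34)nn2)c([N+](=O)[O-])c1` gives > 25000 nM, which is a limit and not a number. Compound 2 `Clc1ccc(-n2cc(COc3cccc4cnc(Nc5cccc(Cl)c5)nc34)nn2)cc1` gives > 25000 nM, which is also a limit and not a number. Among the compounds with values here, compound 2 therefore has no numerical position in this assay, and the one other value available offers no number either. The evidence so far is the limit of > 25000 nM in this assay, at which 2 of the 2 values shown sit.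

Compound 3 `COc1ccccc1-n1cc(COc2cccc3cnc(Nc4cccc(Cl)c4)nc23)nn1` carries 2-methoxyphenyl in place of 4-chlorophenyl on an aromatic nitrogen of a five-membered aromatic ring with 3 nitrogen (2-methoxyphenyl in place of 4-chlorophenyl on an aromatic nitrogen). This swaps one six-membered aromatic ring of carbon only for another and brings in a hydrogen-bond acceptor.

Within the data shown here, the only measured step bearing on this change is a step that the two limits leave unreadable from compound 1 to compound 2, which also alters the group on the aromatic nitrogen. It offers no size or direction to carry over, so no step beyond the scatter is expected in this assay. The expected step is a number no higher from compound 2 to compound 3 (the limit leaves the size open). Compound 3 is estimated at 25000 nM, with an expected range from 10000 nM to 50000 nM, and a report as a limit is the likeliest outcome.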

Compound 3, half-maximal inhibitory concentration: > 25000 nM
Compound 3: only a limit was reported; the forecaster's own chance of this, stated with the estimate: 80%; the middle value sits exactly at the limit.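

In this assay compound 3 gives > 25000 nM, which is a limit and not a number. Within the data shown here, no step can therefore be read among compound 1, compound 2 and compound 3. The compounds shown leave open whether any group on the aromatic nitrogen of the shared core would give a number rather than a limit in this assay.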